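A fluoropyridine in place of the ester-bearing ring

A few compounds are considered here, and "the series" means these few. Any claim that something is new, unique, unknown or untested is made for them only; others in the source may bear on it.

Measured compounds:
Compound 1, `CCS(=O)(=O)Nc1cc(-c2ccc3ncnc(Nc4cccc(F)c4)c3c2)cnc1OC`: 8020 nM
Compound 2, `CCS(=O)(=O)Nc1cc(-c2ccc3ncnc(Nc4ccc(OC)cc4)c3c2)cnc1OC`: 1790 nM
Compound 3, `CCS(=O)(=O)Nc1cc(-c2ccc3ncnc(Nc4cccc(C(=O)OC)c4)c3c2)cnc1OC`: 10100 nM

All three share a common core and differ only in the aromatic ring carried on its nitrogen. In a functional assay on MCF7 cells (Homo sapiens) for cytotoxicity, read by sulforhodamine B assay, with a stated time of 72 h (a higher number here means a weaker inhibitor, a lower number a stronger inhibitor), compound 3 gives the highest of the three numbers. Its nearest neighbour is compound 1, and that gap, a 1.3-fold higher number from compound 1 to compound 3 (0.10 log units; within the scatter), is within the scatter, so the two cannot be ordered. The furthest is compound 2, and that gap, a 5.6-fold higher number from compound 2 to compound 3 (0.75 log units; beyond the scatter), is modest but real.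

Compound 4, `CCS(=O)(=O)Nc1cc(-c2ccc3ncnc(Nc4ccc(F)nc4)c3c2)cnc1OC`, has not yet been measured. It arises from compound 3 by a single change: 6-fluoropyridin-3-yl in place of 3-(methoxycarbonyl)phenyl on a nitrogen on an aromatic ring.

Within the data shown here, two measured steps bear on this. The step of a 1.3-fold higher number from compound 1 to compound 3 (0.10 log units; within the scatter) shows that exchanging fluoro for methoxycarbonyl at this ring made no difference beyond the scatter. The step of a 5.6-fold higher number from compound 2 to compound 3 (0.75 log units; beyond the scatter) shows that a whole-ring swap at this nitrogen can shift the number modestly. Compound 4 carries a fluorine again, though on a ring containing a nitrogen, so the expected step of a 1.7-fold lower number from compound 3 to compound 4 (0.23 log units; within the scatter) is small, toward a somewhat lower number, and may well fall within the scatter.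

Compound 4 is therefore expected to give about 6000 nM, with a range from 2000 nM to 20000 nM.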

Compound 4, half-maximal inhibitory concentration: 5390 nM
Estimate against measurement, compound 4: 1.1-fold (0.05 log units) above; measured number inside the range.
By their numbers in this assay, from the lowest: compound 2; then compounds 4, 1 and 3 (each within the scatter of the next).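

In this assay, moving to the smaller 6-fluoropyridin-3-yl ring gives a 1.9-fold lower number from compound 3 to compound 4 (0.27 log units; within the scatter), and replacing 3-fluorophenyl with the same ring gives a 1.5-fold lower number from compound 1 to compound 4 (0.17 log units; within the scatter), so compound 4 cannot be ordered against either compound. A ring with a nitrogen in it therefore joins a fluorinated carbon ring and an ester-bearing carbon ring in one group, with no difference among the three that stands clear of the scatter. The 4-methoxyphenyl ring remains the only one set apart at this position, now also by a 3.0-fold higher number from compound 2 to compound 4 (0.48 log units; beyond the scatter), a modest step that makes compound 2 the compound with the lowest number of the four, and nothing measured here explains that difference.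

The compounds shown leave open whether the lower number of compound 2 belongs to the methoxy group itself or to where it sits on the ring. They also leave open how this position would respond to a ring carrying an amine or a carboxylic acid, or to a longer chain such as ethoxy in place of methoxy.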